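Notes on the ring-nitrogen aryl group of compound 1

A few compounds are considered here, and "the series" means these few. Any claim that something is new, unique, unknown or untested is made for them only; others in the source may bear on it.

compound 1 `COc1ccc(OC)c(N2C(=O)CSC2c2cccc(C(=O)NCCCCc3ccccc3)c2)c1`: 48%
compound 2 `COc1ccccc1N1C(=O)CSC1C(=O)NCCCCc1ccccc1`: 14%

For the measured compounds named here, in a functional assay on SJSA-1 cells (Homo sapiens) for inhibition, read by CCK-8 assay, with a stated time of 72 h, tested at 1 uM (a lower number here means less inhibition, a higher number more inhibition at the concentration tested (going by the name of the read-out)), compound 1 gives 48%, the higher of the two numbers measured so far. Compound 2 gives 14%, a gap beyond the usual scatter, but the two structures differ in more than one place, so this gap cannot be tied to any single change. Compound 3 `O=C(NCCCCc1ccccc1)c1cccc(C2SCC(=O)N2c2ccccc2)c1` is not yet measured and differs from compound 1 in one place: phenyl in place of 2,5-dimethoxyphenyl on an amide-type nitrogen in a ring. Going by the values given here, no measured pair isolates this change. A moderate fall is expected, a number 13 percentage points lower from compound 1 to compound 3 (beyond the scatter), possibly no larger than the scatter. For compound 3 the estimate is 35%, with a range from 15% to 55%.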

Compound 3, a percentage reported as inhibition, at one concentration (the size of the read-out at that concentration, not a potency): 73%
The estimate for compound 3 lay 38 percentage points below the measured number, outside the stated range (above it).
By their numbers in this assay, from the lowest: compound 2; then compound 1; then compound 3.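

In this assay, replacing 2,5-dimethoxyphenyl with phenyl on the amide-type nitrogen in a ring gives a number 25 percentage points higher from compound 1 to compound 3 (beyond the scatter). For the compounds shown here, this is the first one-place reading at this position, and it shows that inhibition at the concentration tested does not depend on the two methoxy groups of compound 1. Nothing available explains the rise.

Still open, from the compounds shown here alone, is whether a single methoxy on the phenyl would keep the number of compound 3 or lower it. A fluoro, a chloro or a methyl there also remains to be placed against compound 3.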